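The compounds below may be only part of what the source reports. "The series", "measured", "known", "first", "only" and "open" are said of these compounds alone.

Measured compounds in an ADME assay on Raji cells (Homo sapiens) for cytotoxicity, read by luminescence, with a stated time of 72 h; on this read-out higher numbers stand for an effect only at larger amounts of compound and lower numbers for an effect already at smaller amounts:
compound 1 `CCOC(=O)c1c(-c2cc(F)cc(OC)c2)[nH]c2cc(OC)ccc2c1=O` — > 21500 nM, a limit of the assay.
compound 2 `CCOC(=O)c1c(-c2cccc(OCC)c2)[nH]c2cc(OC)ccc2c1=O` — > 21500 nM, also a limit of the assay.

Compound 2 therefore has no number in this assay, only a limit. Within the data shown here, the one step, a step that the two limits leave unreadable from compound 1 to compound 2, is unreadable, since both of its ends sit at the limit of > 21500 nM in this assay, at which 2 of the 2 values shown sit.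

Compound 3 `CCOC(=O)c1c(-c2cccc(OC(F)(F)F)c2)[nH]c2cc(OC)ccc2c1=O` differs from compound 2 by trifluoromethyl in place of ethyl on an oxygen on an aromatic ring. Among the measured compounds shown here, no measured step bears on this change; the only step, from compound 1 to compound 2, gives no readable size. With both measured values at the same limit, no step beyond the scatter is expected in this assay, and the step that the limit leaves unreadable from compound 2 to compound 3 is taken as the estimate. Compound 3 is thus estimated at 30000 nM, with a range from 12000 nM to 80000 nM, and the assay is most likely to report a limit again.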

Compound 3, half-maximal effective concentration: > 21500 nM
Compound 3 was reported as a limit (the forecaster's own chance of this, stated with the estimate: 80%); the middle value does not contradict the limit.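

Compound 2 and compound 3 give no readable step in this assay, as both sit at a limit of the assay: the limit of > 21500 nM in this assay, at which 3 of the 3 values shown sit.

The compounds shown leave open how ethoxy and trifluoromethoxy compare in this assay, and whether any change on the shared core gives a number rather than a limit.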